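Working notes: from compound 2 to compound 3

This account rests on a few compounds, and the source may have more. Where it says the series, first, only, none or still open, it means among the compounds named here.

In a functional assay on KU812 cells for cytotoxicity against KU812 cell line (Homo sapiens), read by MTT assay, with a stated time of 48 h (on this read-out lower numbers stand for an effect already at smaller amounts and higher numbers for an effect only at larger amounts of compound), compound 1 `Nc1cccc(Nc2nc3ccccc3nc2C(=O)O)c1` gives 63800 nM and compound 2 `O=C(O)c1nc2ccccc2nc1Nc1ccc(O)cc1` gives 41700 nM. Going by the values given here, these are the only two numbers, and they lie within the scatter of each other, so compound 2 is not separated from compound 1. The next structure is compound 3 `O=C(O)c1nc2ccccc2nc1Nc1ccccc1O`, with 2-hydroxyphenyl in place of 4-hydroxyphenyl on a nitrogen on an aromatic ring. Among the compounds with values here, only one measured step bears on this place, a 1.5-fold lower number from compound 1 to compound 2 (0.18 log units; within the scatter), and it stays within the scatter. Within the data shown here, no measured step tests a change of this kind directly, so the expectation in this assay is for no shift beyond the scatter, in either direction. The expected step is a 1.1-fold higher number from compound 2 to compound 3 (0.03 log units; within the scatter). For compound 3 the estimate is 45000 nM, with an expected range of 15000 nM to 100000 nM.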

Compound 3, half-maximal effective concentration: 178000 nM
For compound 3 the middle estimate is 4.0-fold (0.60 log units) below the measured one, outside the stated range (above it).
By their numbers in this assay, from the lowest: compounds 2 and 1 (each within the scatter of the next); then compound 3.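

In this assay this place on the nitrogen on an aromatic ring turns out to be sensitive to the change: 2-hydroxyphenyl in place of 4-hydroxyphenyl, with the same atoms and the same counted features, gives a 4.3-fold higher number from compound 2 to compound 3 (0.63 log units; beyond the scatter). Going by these compounds alone, the only earlier step here stayed within the scatter, so this is the first change at this place that separates two compounds, and 2-hydroxyphenyl in place of 3-aminophenyl also gives a 2.8-fold higher number from compound 1 to compound 3 (0.45 log units; beyond the scatter). Nothing available explains the shift.

Going by these compounds, whether a methoxy group or an amine in place of the hydroxyl of 2-hydroxyphenyl would keep the higher number remains open. On these data alone, it is also open whether the same step would appear with an amide in place of the carboxylic acid of the shared core.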